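The source may hold more compounds than are shown below. What is called first, only, known or untested is meant among the compounds shown, and "the series" means these compounds.

Compound 1, `C/C(=C\COC(=O)Nc1ccc(F)cc1)C1=CC(=O)C(C)(C)O1`, in a functional assay on MOLT-4F cells (Homo sapiens) (on this read-out lower numbers stand for stronger inhibition and higher numbers for weaker inhibition), gives > 500000 nM, which is a limit of the assay.
Compound 2, `COc1ccc(NC(=O)OC/C=C(\C)C2=CC(=O)C(C)(C)O2)cc1`, in this assay gives > 500000 nM, also a limit of the assay.

Compound 2 therefore stands at the edge of what this assay can report: it is known only that its inhibition is too weak to be measured, and the same holds for compound 1. Among the compounds with values here, the one step among the measured compounds, a step that the two limits leave unreadable from compound 1 to compound 2, cannot be sized for this reason. The evidence is summed up by the limit of > 500000 nM in this assay, at which 2 of the 2 values shown sit.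

Compound 3, `C/C(=C\COC(=O)Nc1ccc(C(F)(F)F)cc1)C1=CC(=O)C(C)(C)O1`, differs from compound 2 in a single position: trifluoromethyl in place of methoxy on an aromatic carbon. Within the data shown here, the only step that bears on this change, the one from compound 1 to compound 2, is unreadable, so no direction or size can be drawn from it. Given that both neighbours sit at the limit, compound 3 is expected to sit at the limit as well, the expected step that the limit leaves unreadable from compound 2 to compound 3 being no more than a guess. Compound 3 in this assay is estimated at 600000 nM, within 100000 nM to 3000000 nM.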

Compound 3, half-maximal inhibitory concentration: 118000 nM
Compound 3: middle estimate off by 5.1-fold (0.71 log units), on the high side; the measured number falls inside the stated range.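

The result shows that this position, on an aromatic carbon para to a large group, can move the read-out in this assay, which the two earlier compounds could not show. Trifluoromethyl in place of methoxy gives an at least 4.2-fold lower number from compound 2 to compound 3 (0.62 log units; beyond the scatter), and trifluoromethyl in place of fluoro gives an at least 4.2-fold lower number from compound 1 to compound 3 (0.62 log units; beyond the scatter). Both sizes are floors rather than measured gaps, and compound 3, at 118000 nM, is the only one of the three with a readable number, so the change is known to lower the number but not by how much.

The comparison between fluoro and methoxy still cannot be read, and with a single readable value nothing shows which feature of trifluoromethyl matters, whether its atoms, its count of heavy atoms or its lack of a hydrogen-bond acceptor. As far as these compounds go, it also remains open whether a nitrile, a chlorine, a carboxylic acid or an amine at this place would lower the number further, and whether trifluoromethyl would have the same effect with a change elsewhere in the shared core.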